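A few compounds are considered here, and "the series" means these few. Any claim that something is new, unique, unknown or untested is made for them only; others in the source may bear on it.

Of the compounds shown here, three of a shared core have been measured in a physicochemical assay for lipophilicity, measured as octanol-water partition; a higher number here means a more lipophilic compound, a lower number a more polar compound. Compound 1 `C/C(CC(=O)Nc1nnc(-c2ccc(O)cc2)s1)=N\c1ccccn1` gives 3.43. Compound 2 `C/C(CC(=O)Nc1nnc(/C=C/c2ccccc2)s1)=N\c1ccc([N+](=O)[O-])cn1` gives 4.13. Compound 3 `C/C(CC(=O)Nc1nnc(-c2ccc(N)cc2)s1)=N\c1ccc([N+](=O)[O-])cn1` gives 3.21. Compound 3 has the lowest of the three numbers: its gap to compound 1 lies within the scatter, while compound 2 is higher by a step beyond the scatter. Within the data shown here, the only single-point change among the measured compounds is a number 0.92 log units lower from compound 2 to compound 3 (beyond the scatter).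

Compound 4 `C/C(CC(=O)Nc1nnc(-c2ccc(N)cc2)s1)=N\c1ccccn1` is not yet measured. Compared with compound 3 the change is hydrogen in place of nitro on an aromatic carbon; cut one bond further out it reads 5-nitropyridin-2-yl to pyridin-2-yl. Among the measured compounds shown here, no measured step covers this change: the step from compound 2 to compound 3 alters the other end of the molecule, and compound 1 differs from compound 3 in two places at once, so its value shows only that a compound without nitro can sit within the scatter of compound 3. The loss of a group with two hydrogen-bond acceptors would be expected to make the number for compound 4 at most modestly lower, and the estimated step is a number 0.16 log units lower from compound 3 to compound 4 (within the scatter), likely within the scatter. The estimate for compound 4 in this assay is 3.05, with a range from 2.6 to 3.5.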

Compound 4, partition coefficient: 3.3
Compound 4: the middle estimate sits 0.25 log units below what was measured; measured number inside the range.
By their numbers in this assay, from the lowest: compounds 3, 4 and 1 (each within the scatter of the next); then compound 2.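

In this assay, going from 5-nitropyridin-2-yl to pyridin-2-yl gives a number 0.09 log units higher from compound 3 to compound 4 (within the scatter), so with 4-aminophenyl at the other end of the molecule, removing nitro from this aromatic carbon, two atoms from the ring nitrogen, leaves no difference that can be told from the scatter of repeated measurements. The second new comparison, amino in place of hydroxy on an aromatic carbon with pyridin-2-yl held fixed, gives a number 0.13 log units lower from compound 1 to compound 4 (within the scatter) and also stays within the scatter, so the two changes that separate compound 1 from compound 3 have now each been read alone. No measurement shown here gives a reason why either change leaves the number so little altered.

As far as these compounds go, both readings come from a single setting, so it remains open whether removing nitro would look the same in a compound carrying the 2-phenylethenyl group of compound 2. From the compounds shown here alone, it is also open whether a chlorine, a methoxy group or a carboxylic acid on this same aromatic carbon would stay within the scatter of hydrogen and nitro, or would move the number beyond it.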